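The source may hold more compounds than are shown below. What is called first, only, known or untested is meant among the compounds shown, and "the series" means these compounds.

Among the compounds with values here, in a functional assay on CCRF-SB cells (Homo sapiens) for antiproliferative activity, read by MTT assay, with a stated time of 96 h (a higher number here means a weaker inhibitor, a lower number a stronger inhibitor), compound 1 `O=C1NC(=O)C2(CSC3=C2C(=O)c2ncccc2C3=O)N1` gives 150 nM, the highest of the three numbers measured so far. Compound 2 `Cc1ccc(N2C(=O)NC3(CSC4=C3C(=O)c3ncccc3C4=O)C2=O)cc1` gives 20 nM, and compound 3 `O=C1NN(c2ccc([N+](=O)[O-])cc2)C(=O)C2(CSC3=C2C(=O)c2ncccc2C3=O)N1` gives 2 nM. Compound 1 thus stands at the top of the set: its nearest neighbour is compound 2, its furthest compound 3, and both gaps lie beyond the scatter. Within the data shown here, only one step between measured compounds changes a single place, and that is a 7.5-fold lower number from compound 1 to compound 2 (0.88 log units; beyond the scatter), the step that puts 4-methylphenyl on the ring nitrogen of the core.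

Compound 4 `CCCCc1ccc(N2C(=O)NC3(CSC4=C3C(=O)c3ncccc3C4=O)C2=O)cc1` has not yet been measured. It differs from compound 1 by 4-butylphenyl in place of hydrogen on an amide-type nitrogen in a ring. The change sits at the same nitrogen as the step from compound 1 to compound 2, and again places a substituted phenyl there, so that step is the one that bears on the present case. A lower number of comparable size is therefore expected for compound 4, because of a 7.5-fold lower number from compound 1 to compound 2 (0.88 log units; beyond the scatter) seen for the 4-methylphenyl analogue. Compound 4 is estimated to give 20 nM in this assay, with a range from 7 nM to 60 nM. The expected step is a 7.5-fold lower number from compound 1 to compound 4 (0.88 log units; beyond the scatter).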

Compound 4, half-maximal inhibitory concentration: 190 nM
For compound 4 the middle estimate is 9.5-fold (0.98 log units) below the measured one; measured number above the stated range.
By their numbers in this assay, from the lowest: compound 3; then compound 2; then compounds 1 and 4 (each within the scatter of the next).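

At this ring nitrogen, a substituted phenyl does not by itself bring the lower number: in this assay the 4-butylphenyl group gives a 1.3-fold higher number from compound 1 to compound 4 (0.10 log units; within the scatter), which is within the scatter, whereas the 4-methylphenyl group gave a 7.5-fold lower number from compound 1 to compound 2 (0.88 log units; beyond the scatter). What separates the two aryl compounds is the chain on the phenyl ring, and extending methyl to butyl gives a 9.5-fold higher number from compound 2 to compound 4 (0.98 log units; beyond the scatter), so among compounds 1, 2 and 4 the result at this nitrogen depends on what the phenyl ring carries and not merely on the ring being present. Nothing measured alongside these compounds accounts for this difference.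

The compounds shown leave open how the number behaves for ethyl or propyl on the phenyl ring, and thus whether it climbs gradually or abruptly between methyl and butyl. They also leave open what a branched tert-butyl group, a methoxy group, an amine or a carboxylic acid would do on that ring, while compound 3 differs from compounds 1, 2 and 4 in more than one place and cannot settle these questions.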